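Swapping an aminocyclohexanol for imidazole on a nitro-bearing ring

The compounds below may be only part of what the source reports. "The series", "measured", "known", "first", "only" and "open" are said of these compounds alone.

Measured compounds:
Compound 1 `COc1cc[nH]c1/C=C1\C(=O)Nc2ccc([N+](=O)[O-])cc21`: 7460 nM
Compound 2 `COc1cc[nH]c1/C=C1\C(=O)Nc2ccc([N+](=O)[O-])c(N[C@H]3CC[C@H](O)CC3)c21`: 8550 nM

Among the compounds with values here, in a functional assay on MDA-MB-435 cells (Homo sapiens) for antiproliferative activity, read by MTT assay, with a stated time of 5 days (a higher number here means a weaker inhibitor, a lower number a stronger inhibitor), compound 2 gives 8550 nM, and its only neighbour is compound 1, separated by a 1.1-fold higher number from compound 1 to compound 2 (0.06 log units; within the scatter), so the two cannot be told apart. Compound 3 `COc1cc[nH]c1/C=C1\C(=O)Nc2ccc([N+](=O)[O-])c(-n3ccnc3)c21` carries 1H-imidazol-1-yl in place of (4-hydroxycyclohexyl)amino on an aromatic carbon. Within the data shown here, no measured step involves imidazole; the single step shows only that adding a group at this place changed little. Compound 3 is therefore expected to move by about a 1.1-fold lower number from compound 2 to compound 3 (0.03 log units; within the scatter), with no shift beyond the scatter. Compound 3 is estimated at 8000 nM, between 3000 nM and 25000 nM.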

Compound 3, half-maximal inhibitory concentration: > 30000 nM
Compound 3: only a limit was reported; the forecaster's own chance of this, stated with the estimate: 5%; at least 3.7-fold (0.57 log units) between middle value and limit.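

Replacing hydrogen with 1H-imidazol-1-yl gives an at least 4.0-fold higher number from compound 1 to compound 3 (0.60 log units; beyond the scatter) and replacing (4-hydroxycyclohexyl)amino with it gives an at least 3.5-fold higher number from compound 2 to compound 3 (0.54 log units; beyond the scatter) so the group on this aromatic carbon, ortho to a nitro group, can matter after all. As far as these compounds go, both steps rest on a limit for compound 3, so their full size stays unknown: the limit of > 30000 nM in this assay, at which 1 of the 3 values shown sits.

From the compounds shown here alone, whether this loss belongs to imidazole alone or to any aromatic ring at this place stays open. A phenyl ring or a simple dimethylamino group here could help separate those two readings.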